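Swapping the aryl group next to the carbonyl

The source may report more compounds than this note shows. Statements on the series, on what has been measured and on what is new or still open speak of the compounds shown alone.

Of the compounds shown here, two of one family have been measured in a functional assay on T47D cells (Homo sapiens) for inhibition, read by sulforhodamine B assay, with a stated time of 48 h; on this read-out lower numbers stand for stronger inhibition of growth and higher numbers for weaker inhibition of growth. Compound 1 `COc1cc(-c2cc(/C=C/C(=O)c3ccc(Cl)c(Cl)c3)[nH]n2)cc(OC)c1OC` gives 15700 nM. Compound 2 `COc1ccc(C(=O)/C=C/c2cc(-c3cc(OC)c(OC)c(OC)c3)n[nH]2)cc1` gives 13000 nM. On these numbers compound 2 has the lower of the two readings, yet the gap to compound 1 is within the scatter, so no order between them can be claimed. The step of a 1.2-fold lower number from compound 1 to compound 2 (0.08 log units; within the scatter) is the only one available. Compound 3 `COc1cc(-c2cc(/C=C/C(=O)c3ccc(F)c(F)c3)[nH]n2)cc(OC)c1OC` differs from compound 2 by 3,4-difluorophenyl in place of 4-methoxyphenyl on a carbonyl carbon. This change brings the group back toward the kind seen in compound 1, where two halogens sit on the same ring positions, and the step from compound 1 to compound 2 was within the scatter. A step of similar small size is therefore expected, with no direction beyond the scatter, giving an estimated 1.2-fold higher number from compound 2 to compound 3 (0.06 log units; within the scatter) in this assay. Compound 3 is thus expected to give about 15000 nM, with a range of 6000 nM to 40000 nM.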

Compound 3, concentration for total growth inhibition: 27000 nM
Compound 3: middle estimate off by 1.8-fold (0.26 log units), on the low side, within the range that was stated.
By their numbers in this assay, from the lowest: compounds 2, 1 and 3 (each within the scatter of the next, the first and the last beyond it).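

In this assay, the group on the carbonyl carbon now produces a step beyond the scatter: 3,4-difluorophenyl in place of 4-methoxyphenyl gives a 2.1-fold higher number from compound 2 to compound 3 (0.32 log units; beyond the scatter), modest in size, so this position is not fully indifferent to the group it carries, which compounds 1 and 2 alone could not show. The two dihalogenated groups stay closer together, since 3,4-difluorophenyl in place of 3,4-dichlorophenyl gives a 1.7-fold higher number from compound 1 to compound 3 (0.24 log units; within the scatter), and fluorine and chlorine on this ring cannot be told apart here. No measurement is available that explains either step.

As far as these compounds go, whether a phenyl ring carrying an amine or a carboxylic acid would shift the number further remains open. So does whether a longer chain in place of the ring would be tolerated at this carbonyl carbon.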